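Shifting an Ethoxy Group Around a Phenyl Ring

A few compounds are considered here, and "the series" means these few. Any claim that something is new, unique, unknown or untested is made for them only; others in the source may bear on it.

Compound 2 `CCOc1ccccc1Nc1nc(SCc2ccc(C(F)(F)F)cc2)nc2ccccc12` carries a 2-ethoxyphenyl on a nitrogen on an aromatic ring of the shared core. In a functional assay on HGC-27 cells (Homo sapiens) for cytotoxicity, read by MTT assay, with a stated time of 72 h (a lower number here means a stronger inhibitor, a higher number a weaker inhibitor), compound 2 gives > 50000 nM, which is a limit of the measurement rather than a number. Compound 2 thus stands at the weak end of the three measured compounds, being the one that reached (the limit of > 50000 nM in this assay, at which 1 of the 3 values shown sits). Compound 1 `CCCCCCNc1nc(SCc2ccc(C(F)(F)F)cc2)nc2ccccc12`, with a hexyl in the same place, gives 23900 nM in this assay, and compound 3 `FC(F)(F)c1ccc(CSc2nc(Nc3ccc(Cl)cc3)c3ccccc3n2)cc1`, with a 4-chlorophenyl there, gives 14100 nM. The step of an at least 2.0-fold higher number from compound 1 to compound 2 (0.32 log units; beyond the scatter), while the step of an at least 3.5-fold lower number from compound 2 to compound 3 (0.54 log units; beyond the scatter). The step of a 1.7-fold lower number from compound 1 to compound 3 (0.23 log units; within the scatter).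

Compound 4 `CCOc1ccc(Nc2nc(SCc3ccc(C(F)(F)F)cc3)nc3ccccc23)cc1` is built from the same atoms as compound 2, joined differently: 4-ethoxyphenyl in place of 2-ethoxyphenyl on a nitrogen on an aromatic ring. The step from compound 2 to compound 3 bears most directly on this change, since it too removes the 2-ethoxyphenyl and puts a group named with a 4-position in its place, and that step lay beyond the scatter. A step of similar direction is therefore expected here, though the group that enters differs from the 4-chlorophenyl of compound 3, so the expectation is held loosely. Compound 4 is expected to show an at least 2.0-fold lower number from compound 2 to compound 4 (0.30 log units; that floor lies within the scatter) in this assay. The estimate for compound 4 is 25000 nM, with a range from 10000 nM to 60000 nM.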

Compound 4, half-maximal inhibitory concentration: 33000 nM
Compound 4: the middle estimate sits 1.3-fold (0.12 log units) below what was measured; measured number inside the range.
By their numbers in this assay, from the lowest: compounds 3, 1 and 4 (each within the scatter of the next, the first and the last beyond it). At a limit, above all of these: compound 2.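

Compound 2 remains a limit of the measurement rather than a number: the limit of > 50000 nM in this assay, at which 1 of the 4 values shown sits.

Moving the ethoxy group from the 2-ethoxyphenyl to the 4-ethoxyphenyl arrangement brings the value in this assay into measurable range, but the change can be stated only as an at least 1.5-fold lower number from compound 2 to compound 4 (0.18 log units; that floor lies within the scatter), so its true size remains unknown. With the 4-substituted phenyl kept, ethoxy in place of chloro on an aromatic carbon gives a 2.3-fold higher number from compound 3 to compound 4 (0.37 log units; beyond the scatter), which shows that the identity of the group on the phenyl ring can matter as well as its place, while 4-ethoxyphenyl in place of hexyl gives a 1.4-fold higher number from compound 1 to compound 4 (0.14 log units; within the scatter).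

The compounds shown leave open whether an amine or a carboxylic acid in place of the ethoxy group would give a number closer to that of the ethoxy compound or the chloro compound. They also cannot tell whether a 2-chlorophenyl would reach a limit as compound 2 does, a comparison that would show whether the penalty seen with compound 2 belongs to the 2-substituted arrangement or to the ethoxy group alone.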